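Adding dimethoxy groups to the aryl group of compound 3

The compounds below may be only part of what the source reports. "The series", "measured", "known", "first", "only" and "open" are said of these compounds alone.

In a functional assay on cells (Homo sapiens) for antiproliferative activity, read by sulforhodamine B assay, with a stated time of 48 h (on this read-out lower numbers stand for stronger inhibition and higher numbers for weaker inhibition), compound 1 (`CCCCCCCCCCCCCCCCNC(=O)[C@@H]1CSC(c2cc(OC)c(OC)c(OC)c2)N1`) gives 1800 nM and compound 2 (`CCCCCCCCCCCCCCCCNC(=O)[C@@H]1CSC(c2ccc(NC(C)=O)cc2)N1`) gives 2100 nM. Compound 3 (`CCCCCCCCCCCCCCNC(=O)[C@@H]1CSC(c2ccccc2)=N1`) gives 42100 nM, the highest of the three numbers and beyond the scatter of both others. It differs from both in more than the aryl group: it has a carbon with a double bond to nitrogen, and its amide chain is tetradecyl rather than hexadecyl. The gap cannot be assigned to any one of these changes.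

Compound 4 (`CCCCCCCCCCCCCCNC(=O)[C@@H]1CSC(c2ccc(OC)c(OC)c2)=N1`) carries 3,4-dimethoxyphenyl in place of phenyl on a carbon with a double bond to nitrogen. For the measured compounds named here, the only measured aryl swap is a 1.2-fold higher number from compound 1 to compound 2 (0.07 log units; within the scatter), on a saturated ring carbon, and no measured pair starts from phenyl. With that single step as a guide, no step beyond the scatter is expected in this assay. The expected change is a 1.4-fold lower number from compound 3 to compound 4 (0.15 log units; within the scatter). The estimate for compound 4 is 30000 nM, with an expected range from 9000 nM to 70000 nM.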

Compound 4, half-maximal inhibitory concentration: 19100 nM
Beside the measured number, compound 4's estimate is 1.6-fold (0.20 log units) above it, within the range that was stated.
By their numbers in this assay, from the lowest: compounds 1 and 2 (each within the scatter of the next); then compound 4; then compound 3.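

For the compounds shown here, on the carbon with a double bond to nitrogen of the shared core, with the tetradecyl amide chain held constant, this assay gives the first aryl step beyond the scatter: a 2.2-fold lower number from compound 3 to compound 4 (0.34 log units; beyond the scatter). Going by these compounds alone, the step is modest, but it shows that the aryl group at this position can shift the read-out, which the only earlier aryl swap, a 1.2-fold higher number from compound 1 to compound 2 (0.07 log units; within the scatter), did not show; that swap was on a saturated ring carbon and involved different groups. No measurement at hand bears on the origin of this step.

As far as these compounds go, it remains open whether both methoxy groups are needed for the step, or whether one alone would give it. Also open, from the compounds shown here alone, is whether an amine or a carboxylic acid in their place, or a longer chain on the amide, would move the number further.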